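The source may hold more compounds than are shown below. What is called first, only, known or untested is meant among the compounds shown, and "the series" means these compounds.

Compound 1 `COc1cc(N2C(=O)[C@@H](Oc3ccccc3)[C@H]2c2ccc(Br)cc2)cc(OC)c1OC`: 48000 nM; compound 2 `COc1cc(N2C(=O)[C@@H](Oc3ccccc3)[C@H]2c2ccc(O)cc2)cc(OC)c1OC`: 48000 nM.

In a functional assay on MCF7 cells (Homo sapiens) for antiproliferative activity, read by MTT assay, with stated times of 24 h and 72 h (on this read-out lower numbers stand for stronger inhibition and higher numbers for weaker inhibition), compound 1 gives 48000 nM. Compound 2 stands level with it, and the step of no change at the digits printed from compound 1 to compound 2 (within the scatter) shows no change beyond the scatter. Compound 3 `COc1cc(N2C(=O)[C@@H](Oc3ccccc3)[C@H]2c2ccc(N)cc2)cc(OC)c1OC` differs from compound 2 in one place: amino in place of hydroxy on an aromatic carbon. Among the compounds with values here, only one step bears on this change, the one from compound 1 to compound 2, and it was flat. On that basis compound 3 is expected to stay close to compound 2, with a step of no change at the digits printed from compound 2 to compound 3 (within the scatter), so its value in this assay is estimated at 48000 nM, in the range 20000 nM to 120000 nM.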

Compound 3, half-maximal inhibitory concentration: 160000 nM
Compound 3: the middle estimate sits 3.3-fold (0.52 log units) below what was measured, and the stated range ends below it.
By their numbers in this assay, from the lowest: compounds 1 and 2 (each within the scatter of the next); then compound 3.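

In this assay the aromatic carbon para to a large group proved sensitive to what it carries: the flat result for bromo and hydroxy did not extend to amino, giving a 3.3-fold higher number from compound 2 to compound 3 (0.52 log units; beyond the scatter) and a 3.3-fold higher number from compound 1 to compound 3 (0.52 log units; beyond the scatter) as the two steps now on record. Of the three groups shown, amino alone stands apart from the others. No measurement at hand accounts for this difference.

Going by these compounds, whether a methoxy group, a carboxylic acid or a dimethylamino group at this position would side with amino or with bromo and hydroxy remains open.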